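The source may report more compounds than this note shows. Statements on the series, on what has been measured and on what is new or still open speak of the compounds shown alone.

Measured in a functional assay on PC-3 cells (Homo sapiens) for antiproliferative activity, read by MTT assay, with a stated time of 48 h; on this read-out higher numbers stand for weaker inhibition and lower numbers for stronger inhibition:
Compound 1 `COc1cc(N(Cc2ccc(C)cc2)C(=O)CSc2nc3ccccc3s2)cc(OC)c1OC`: > 80000 nM (a limit)
Compound 2 `COc1ccc(CN(C(=O)CSc2nc3ccccc3s2)c2cc(OC)c(OC)c(OC)c2)cc1N=[N+]=[N-]`: 14400 nM
Compound 3 `COc1cc(N(Cc2ccccc2)C(=O)CSc2nc3ccccc3s2)cc(OC)c1OC`: 54100 nM
Not yet measured: compound 4 `COc1cc(N(Cc2ccc(Br)cc2)C(=O)CSc2nc3ccccc3s2)cc(OC)c1OC`

Compound 3 holds the higher of the two actual numbers, with a 3.8-fold higher number from compound 2 to compound 3 (0.57 log units; beyond the scatter). The next change is bromo in place of hydrogen on an aromatic carbon. For the measured compounds named here, the closest precedent is the methyl-to-hydrogen change at that same place, with an at least 1.4-fold lower number from compound 1 to compound 3 (0.16 log units; that floor lies within the scatter), a floor and not a measured size. The larger at least 5.5-fold lower number from compound 1 to compound 2 (0.74 log units; beyond the scatter) involves a different group and bears less directly. No shift beyond the scatter is therefore expected, and the estimated change is a 1.1-fold lower number from compound 3 to compound 4 (0.03 log units; within the scatter). Compound 4 may also read out only as a limit. The estimate for compound 4 is 50000 nM, with an expected range of 20000 nM to 100000 nM.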

Compound 4, half-maximal inhibitory concentration: > 80000 nM
Compound 4 was reported as a limit (the forecaster's own chance of this, stated with the estimate: 30%); middle value at least 1.6-fold (0.20 log units) from the limit.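

In this assay, going from benzyl to 4-bromobenzyl gives an at least 1.4-fold higher number from compound 3 to compound 4 (0.16 log units; that floor lies within the scatter), a floor that cannot show whether this change matters. 4-Bromophenyl in place of 3-azido-4-methoxyphenyl gives an at least 5.5-fold higher number from compound 2 to compound 4 (0.74 log units; beyond the scatter), which leaves compound 2 the strongest of the four, with all its steps beyond the scatter. The step between compound 1 and compound 4 cannot be read, as both values are limits: the limit of > 80000 nM in this assay, at which 2 of the 4 values shown sit.

Open, as far as these compounds go, is whether an amine or a carboxylic acid at this place would give a measurable number. Also open, from the compounds shown here alone, is whether azido alone or methoxy alone accounts for the number of compound 2.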